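The source may report more compounds than this note shows. Statements on the series, on what has been measured and on what is new or still open speak of the compounds shown alone.

Compound 2, `COc1ccc(C(=O)Nc2cnccn2)cc1OC1CCCC1`, stands alone among the numbers shown here: in an assay on isolated protein for inhibition of phosphodiesterase 4A (Sus scrofa) (on this read-out lower numbers stand for stronger inhibition and higher numbers for weaker inhibition), compound 2 gives 250 nM. Compound 1, `COc1ccc(C(=O)Nc2cccc(Cl)c2Cl)cc1OC1CCCC1`, gives only a limit of this assay, > 200000 nM. Among the compounds with values here, the step of an at least 800-fold lower number from compound 1 to compound 2 (2.90 log units; beyond the scatter) is the one measured step, and it too changed the group on the amide nitrogen, so it bears on the change now considered, although it rests on a limit of > 200000 nM in this assay, at which 1 of the 2 values shown sits, rather than on two numbers. Compound 3, `COc1ccc(C(=O)Nc2c(C)nsc2C)cc1OC1CCCC1`, differs from compound 2 in that (3,5-dimethyl-1,2-thiazol-4-yl in place of pyrazin-2-yl on an amide-type nitrogen). Both groups are small aromatic rings carrying two hetero atoms, so a step of the size seen between compound 1 and compound 2 is not expected; the measured step only shows that this position tolerates a change of ring. The expected step is a 2.1-fold lower number from compound 2 to compound 3 (0.32 log units; beyond the scatter). Compound 3 is therefore estimated to give about 120 nM in this assay, most likely between 20 nM and 800 nM.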

Compound 3, half-maximal inhibitory concentration: 500 nM
The estimate for compound 3 lay 4.2-fold (0.62 log units) below the measured number; the measured number falls inside the stated range.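

With a 2.0-fold higher number from compound 2 to compound 3 (0.30 log units; within the scatter), pyrazin-2-yl and 3,5-dimethyl-1,2-thiazol-4-yl cannot be told apart in this assay, although one is a six-membered and the other a five-membered aromatic ring. With an at least 400-fold lower number from compound 1 to compound 3 (2.60 log units; beyond the scatter), a second large step appears, so a measurable number at this position does not depend on pyrazin-2-yl alone. This step rests on the limit of compound 1 and not on two numbers: the limit of > 200000 nM in this assay, at which 1 of the 3 values shown sits.

The compounds shown leave open whether the two chlorine atoms or the phenyl ring itself accounts for the limit of compound 1, a question that an unsubstituted phenyl or a pyridin-2-yl group on the same nitrogen could address. Also open, going by these compounds, is how a non-aromatic group, such as a cyclohexyl ring or a longer alkyl chain, behaves at this position.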